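The source may report more compounds than this note shows. Statements on the series, on what has been measured and on what is new or still open speak of the compounds shown alone.

Measured compounds:
compound 1 `COc1ccc(-c2cc(-c3ccc(Cl)cc3)n(C3C(=O)Nc4ccc(Br)cc43)n2)cc1`: 22100 nM
compound 2 `COc1ccc(-c2cc(-c3ccc(Cl)cc3)n(C3C(=O)Nc4ccc(Cl)cc43)n2)cc1`: 20300 nM

Compound 1 `COc1ccc(-c2cc(-c3ccc(Cl)cc3)n(C3C(=O)Nc4ccc(Br)cc43)n2)cc1` and compound 2 `COc1ccc(-c2cc(-c3ccc(Cl)cc3)n(C3C(=O)Nc4ccc(Cl)cc43)n2)cc1` were both tested in a functional assay on cells (Cancer cell lines, Homo sapiens) for cytotoxicity, read by sulforhodamine B assay, with a stated time of 48 h; on this read-out lower numbers stand for stronger inhibition of growth and higher numbers for weaker inhibition of growth. Compound 1 gives 22100 nM, the higher of the two numbers, and compound 2 gives 20300 nM; the step of a 1.1-fold lower number from compound 1 to compound 2 (0.04 log units; within the scatter) lies within the scatter, so the two compounds are not told apart.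

Compound 3 `O=C1Nc2ccc(Br)cc2C1n1nc(-c2ccc3ccccc3c2)cc1-c1ccc(Cl)cc1` has not yet been measured. It differs from compound 1 by the change (naphthalen-2-yl in place of 4-methoxyphenyl on an aromatic carbon). For the measured compounds named here, the only measured step, from compound 1 to compound 2, concerns a different part of the molecule, a halogen swap on the fused ring, and is small; no measured pair touches the group that is changed here. No step beyond the scatter is therefore predicted in this assay, in either direction.

Compound 3 is accordingly expected to give about 18000 nM, with a range from 6000 nM to 55000 nM; the expected step of a 1.2-fold lower number from compound 1 to compound 3 (0.09 log units; within the scatter) is an estimate only.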

Compound 3, concentration for total growth inhibition: 8890 nM
Compound 3: the middle estimate sits 2.0-fold (0.31 log units) above what was measured, and the stated range covers the measured number.
By their numbers in this assay, from the lowest: compound 3; then compounds 2 and 1 (each within the scatter of the next).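

In this assay, for the compounds shown here, this is the first change to the core of compound 1 that moves the number beyond the scatter: the step of a 2.5-fold lower number from compound 1 to compound 3 (0.40 log units; beyond the scatter) shows that growth inhibition responds, modestly, to the group on this aromatic carbon of the five-membered ring, whereas the halogen swap, the step of a 1.1-fold lower number from compound 1 to compound 2 (0.04 log units; within the scatter), did not tell compounds apart. Naphthalen-2-yl in place of 4-methoxyphenyl changes two things at once, adding a second six-membered aromatic ring and removing the oxygen, and this single pair cannot separate them. Nothing available bears on why the number moves.

A plain phenyl group at this position would separate the second ring from the loss of the methoxy group. As far as these compounds go, it also remains open whether naphthalen-2-yl gives a similar step on the chloro compound 2.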